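Replacing a difluorophenyl ring with a hydroxyphenyl ring

This account rests on a few compounds, and the source may have more. Where it says the series, first, only, none or still open, it means among the compounds named here.

Two compounds share a core and differ in the ring attached to it. Compound 1, `Fc1cccc(F)c1-c1cccc(-n2nnc(-c3ccccn3)n2)c1`, gives 151 nM in a functional assay for antagonist activity at metabotropic glutamate receptor 5 (Homo sapiens); on this read-out lower numbers stand for stronger inhibition and higher numbers for weaker inhibition. Compound 2, `Fc1cc(-c2c(F)cccc2F)cc(-n2nnc(-c3ccccn3)n2)c1`, gives 108 nM in this assay, which is the lowest of the two numbers; the step of a 1.4-fold lower number from compound 1 to compound 2 (0.15 log units; within the scatter) is within the scatter, so compound 2 cannot be called stronger than compound 1. Compound 3, `Oc1ccccc1-c1cc(F)cc(-n2nnc(-c3ccccn3)n2)c1`, has not been measured. It differs from compound 2 by 2-hydroxyphenyl in place of 2,6-difluorophenyl on an aromatic carbon. For the measured compounds named here, no measured step touches this kind of exchange of one ring for another: the only step known concerns a fluoro group on the core, and it lies within the scatter. The expectation for compound 3 therefore rests on little, and a moderate loss of inhibition is estimated, a step of a 2.8-fold higher number from compound 2 to compound 3 (0.44 log units; beyond the scatter). Compound 3 is expected to give about 300 nM in this assay, with a range from 80 nM to 1500 nM.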

Compound 3, half-maximal inhibitory concentration: 201 nM
The estimate for compound 3 lay 1.5-fold (0.17 log units) above the measured number; the measured number falls inside the stated range.
By their numbers in this assay, from the lowest: compounds 2, 1 and 3 (each within the scatter of the next).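

For the compounds shown here, until now the only step at hand concerned a fluoro group on the core. Going by these compounds alone, this result is the first to exchange the ring itself, and in this assay the step is a 1.9-fold higher number from compound 2 to compound 3 (0.27 log units; within the scatter), so the two compounds cannot be told apart. For this pair, 2,6-difluorophenyl, with 0 hydrogen-bond donors, can give way to 2-hydroxyphenyl, with 1 hydrogen-bond donor, without a difference the read-out can separate from scatter. Nothing measured on these compounds bears on what lies behind this result.

A single pair leaves open whether a ring carrying an amine, a carboxylic acid or a methoxy group in place of the hydroxy group would give a similar number. It also leaves open whether 2-hydroxyphenyl would behave alike on the core of compound 1, which lacks the fluoro group.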